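Amide-nitrogen change on the thiophen-2-yl compound

The compounds below may be only part of what the source reports. "The series", "measured", "known", "first", "only" and "open" are said of these compounds alone.

Measured so far in an ADME assay on LLC-MK2 cells (Macaca mulatta) for cytotoxicity, read by spectrophotometry and crystal violet staining, with a stated time of 4 days; a higher number here means that more compound is tolerated, a lower number that less compound is tolerated:
Compound 1 `CC(C)n1ncc2c(C(=O)Nc3ncccn3)cc(-c3ccsc3)nc21`: 50000 nM
Compound 2 `CC(C)n1ncc2c(C(=O)Nc3ncccn3)cc(-c3cccs3)nc21`: 75000 nM

In this assay, among the compounds with values here, the two values are not separated, and the single measured step is a 1.5-fold higher number from compound 1 to compound 2 (0.18 log units; within the scatter). Within the data shown here, compound 2 therefore stands level with compound 1 within the scatter, and both values come from only two measurements.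

The next compound is compound 3 `CC(C)n1ncc2c(C(=O)Nc3c(F)cc(F)cc3F)cc(-c3cccs3)nc21`, which differs from compound 2 on an amide-type nitrogen: 2,4,6-trifluorophenyl in place of pyrimidin-2-yl on an amide-type nitrogen. In short, 2,4,6-trifluorophenyl replaces pyrimidin-2-yl.

Among the measured compounds shown here, the one measured step concerns thiophen-2-yl in place of thiophen-3-yl on an aromatic carbon, so it bears only indirectly on this change. It shows that the series tolerated that swap without a step beyond the scatter. For the measured compounds named here, no step has been measured at the amide-type nitrogen, so the size of this change is unknown, and the range is kept wide.

A small downward step is expected, not clearly beyond the scatter. The estimated step is a 1.7-fold lower number from compound 2 to compound 3 (0.22 log units; within the scatter). For compound 3 the expected value is 45000 nM, with an estimated range of 15000 nM to 100000 nM.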

Compound 3, half-maximal cytotoxic concentration: > 200000 nM
Compound 3 ended at the assay's limit; the forecaster's own chance of this, stated with the estimate: 20%; middle value at least 4.4-fold (0.64 log units) from the limit.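

Within the data shown here, the amide-type nitrogen is the first place in this short series where a single change gives a step beyond the scatter in this assay, with 2,4,6-trifluorophenyl in place of pyrimidin-2-yl giving an at least 2.6-fold higher number from compound 2 to compound 3 (0.42 log units; beyond the scatter). Compound 3 gives > 200000 nM, which is a limit of the assay and not a number, so the step marks only a minimum size: the limit of > 200000 nM in this assay, at which 1 of the 3 values shown sits. Among these compounds, the only other measured step, the thiophene swap, is a 1.5-fold higher number from compound 1 to compound 2 (0.18 log units; within the scatter), so across these two steps only the change on the amide-type nitrogen moves the number beyond the scatter.

The compounds shown do not separate the departure of the ring nitrogens of pyrimidin-2-yl from the arrival of the fluorines, and a plain phenyl on the amide-type nitrogen would be the group to read that difference. Also open, on these data alone, is whether 2,4,6-trifluorophenyl gives a step of this kind with thiophen-3-yl, as in compound 1, and how far the tolerated concentration of compound 3 lies past the limit.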